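A few compounds are considered here, and "the series" means these few. Any claim that something is new, unique, unknown or untested is made for them only; others in the source may bear on it.

Notes on the aryl variation in this series. Compound 1 `CC(C)(C)Cc1c(-c2ccc(F)cc2F)sc(N)c1C(=O)c1ccc(Cl)cc1` gives 1% in an assay on CHO cells for displacement of a labelled ligand from adenosine receptor A3 (Homo sapiens), read by scintillation counting, tested at 10 uM; a lower number here means less inhibition, a higher number more inhibition at the concentration tested (going by the name of the read-out). Compound 2 `CC(C)(C)Cc1c(-c2cc(F)ccc2F)sc(N)c1C(=O)c1ccc(Cl)cc1` gives 1%. Compound 3 `CC(C)(C)Cc1c(-c2ccccc2)sc(N)c1C(=O)c1ccc(Cl)cc1` gives 1%. On these numbers compound 3 stands level with compounds 1 and 2, and the three values sit within the scatter of one another, so no order among them can be read. The steps between them are no change at the digits printed from compound 1 to compound 2 (within the scatter), no change at the digits printed from compound 1 to compound 3 (within the scatter) and no change at the digits printed from compound 2 to compound 3 (within the scatter), each a change of the ring on an aromatic carbon of the shared core that left the read-out flat.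

Compound 4 `CC(C)(C)Cc1c(-c2cccs2)sc(N)c1C(=O)c1ccc(Cl)cc1` is not yet measured in this assay. It differs from compound 3 thus: thiophen-2-yl in place of phenyl on an aromatic carbon. Among the measured compounds shown here, the steps that bear on this change are the two that reach compound 3, no change at the digits printed from compound 1 to compound 3 (within the scatter) and no change at the digits printed from compound 2 to compound 3 (within the scatter), both within the scatter, showing that exchange of the ring on this aromatic carbon between phenyl and the two difluorophenyl groups moved nothing. For the measured compounds named here, none of the measured steps replaces a six-membered ring by a five-membered one, so the pair is a new kind of change. With every measured value flat at this level, the expectation for compound 4 is a step of a number 1 percentage points higher from compound 3 to compound 4 (within the scatter), none beyond the scatter. Compound 4 is therefore estimated at 2%, with a range from -8% to 12%.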

Compound 4, a percentage reported as inhibition, at one concentration (the size of the read-out at that concentration, not a potency): 1%
Estimate against measurement, compound 4: 1 percentage points above; the measured number falls inside the stated range.
By their numbers in this assay, from the lowest: compounds 1, 2, 3 and 4 (each within the scatter of the next).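

In this assay, the exchange of phenyl for thiophen-2-yl on the aromatic carbon next to the ring sulfur gives no change at the digits printed from compound 3 to compound 4 (within the scatter). Among the compounds shown here, this is the first change at this position that alters the ring itself, replacing one six-membered aromatic ring of carbon only with one five-membered aromatic ring with 1 hetero atom, and it brings in a ring sulfur, yet the read-out stays flat. The same holds against both fluorinated rings, with thiophen-2-yl in place of 2,5-difluorophenyl giving no change at the digits printed from compound 2 to compound 4 (within the scatter) and thiophen-2-yl in place of 2,4-difluorophenyl giving no change at the digits printed from compound 1 to compound 4 (within the scatter), so across these four compounds neither ring size nor fluorine substitution separates the values, and nothing on hand explains this flatness.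

Still open, going by these compounds, is whether any group at this position would lift the read-out from this level, for example a ring carrying a carboxylic acid or a primary amine, or a longer alkyl chain in place of the ring. On these data alone, the neopentyl group, the amino group and the 4-chlorobenzoyl group are the same in all four compounds, so what a change at any of those places would do also remains unknown.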